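The compounds below may be only part of what the source reports. "The series", "measured", "known", "first", "only" and "open" are said of these compounds alone.

Measured in a physicochemical assay for metabolic stability, read by HPLC and mass spectrometry, in phosphate buffer, at 37 degrees C, at pH 7.4; a higher number here means that the compound lasts longer, a lower number that the compound disappears faster:
Compound 1 `CN(C[C@@H]1[C@H](NC(=O)/C(=N\OC(C)(C)C(=O)O)c2csc(N)n2)C(=O)N1S(=O)(=O)O)C(=O)CN`: 212 h
Compound 2 `CC(C)(O/N=C(\C(=O)N[C@@H]1C(=O)N(S(=O)(=O)O)[C@@H]1CN1CCNC1=O)c1csc(N)n1)C(=O)O`: > 1000 h (a limit)
Compound 3 `CC(C)(O/N=C(\C(=O)N[C@@H]1C(=O)N(S(=O)(=O)O)[C@@H]1CN1C[C@H](CNC(=N)N)OC1=O)c1csc(N)n1)C(=O)O`: > 37 h (a limit)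

Compound 3 has no number, only the limit > 37 h. The next structure is compound 4 `CC(C)(O/N=C(\C(=O)N[C@@H]1C(=O)N(S(=O)(=O)O)[C@@H]1Cn1cc(CO)nn1)c1csc(N)n1)C(=O)O`, and the change to it is a group of 7 heavy atoms (3 carbon, 3 nitrogen, 1 oxygen; one five-membered aromatic ring with 3 hetero atoms) in place of a group of 11 heavy atoms (5 carbon, 4 nitrogen, 2 oxygen; one five-membered non-aromatic ring with 2 hetero atoms), on a saturated chain carbon bound to a saturated ring carbon: 4-(hydroxymethyl)-1H-1,2,3-triazol-1-yl enters on a saturated chain carbon bound to a saturated ring carbon. Going by the values given here, the one step with a readable size is an at least 4.7-fold higher number from compound 1 to compound 2 (0.67 log units; beyond the scatter), which lies beyond the scatter. The other two, a step that the limit leaves unreadable from compound 1 to compound 3 and a step that the two limits leave unreadable from compound 2 to compound 3, cannot be sized. Among the compounds with values here, the expectation therefore rests mainly on compound 1 at 212 h, the only true number. In this assay a modest upward step is expected from the limit figure, though the direction is not firm. The expected step is a step that the limit leaves unreadable from compound 3 to compound 4. Compound 4 is expected at 150 h, with an estimated range from 40 h to 800 h.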

Compound 4, half-life: > 37 h
Compound 4: no number, only a limit; the forecaster's own chance of this, stated with the estimate: 35%; the middle value does not contradict the limit.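

Going by these compounds alone, compound 4 gives only a limit, > 37 h, so no step between it and compound 1, compound 2 or compound 3 can be read. The compounds shown leave open where the half-lives of compound 3 and compound 4 actually lie, and whether 4-(hydroxymethyl)-1H-1,2,3-triazol-1-yl in place of 2-oxoimidazolidin-1-yl changes the half-life at all.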